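A few compounds are considered here, and "the series" means these few. Any claim that something is new, unique, unknown or untested is made for them only; others in the source may bear on it.

Measured so far:
compound 1 `CN(C)C(=O)c1cc2cnc(Nc3ccc(NC(=O)C4(C(=O)Nc5ccc(Cl)c(C(F)(F)F)c5)CC4)cc3)nc2n1C1CCCC1` — 88.1%
compound 2 `CN(C)C(=O)c1cc2cnc(Nc3ccc(NC(=O)C4(C(=O)Nc5ccc(O)cc5)CC4)cc3)nc2n1C1CCCC1` — 94.4%
compound 3 `CN(C)C(=O)c1cc2cnc(Nc3ccc(NC(=O)C4(C(=O)Nc5cccc(F)c5)CC4)cc3)nc2n1C1CCCC1` — 91.8%

All three were read in a functional assay on A549 cells (Homo sapiens) for inhibition, read by CCK-8 assay, with a stated time of 72 h, tested at 10 uM; a lower number here means less inhibition of growth, a higher number more inhibition of growth at the concentration tested. Compound 3 stands second highest of the three numbers. Its nearest neighbour is compound 2, the two being separated by a number 2.6 percentage points lower from compound 2 to compound 3 (within the scatter); its furthest is compound 1, separated by a number 3.7 percentage points higher from compound 1 to compound 3 (within the scatter). Both gaps lie within the scatter. The remaining pair, compound 1 and compound 2, differ by a number 6.3 percentage points higher from compound 1 to compound 2 (within the scatter), also within the scatter.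

Compound 4 `CN(C)C(=O)c1cc2cnc(Nc3ccc(NC(=O)C4(C(=O)Nc5cccc(C#N)c5)CC4)cc3)nc2n1C1CCCC1` differs from compound 3 by one change:
cyano in place of fluoro on an aromatic carbon

Every measured step bears on this case, since each of them exchanges the aryl group on the same amide-type nitrogen, and none of them moved the number beyond the scatter. The replacement of fluoro by cyano on an aromatic carbon of that ring is therefore expected to give no step beyond the scatter, namely a number 1.3 percentage points lower from compound 3 to compound 4 (within the scatter). For compound 4 the estimate in this assay is 90.5%, with a range from 81% to 97%.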

Compound 4, percent growth inhibition at one concentration: 73.6%
For compound 4 the middle estimate is 16.9 percentage points above the measured one; the whole stated range lies above it.
By their numbers in this assay, from the lowest: compound 4; then compounds 1, 3 and 2 (each within the scatter of the next).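

In this assay, among the compounds shown here, the ring on this amide-type nitrogen proved sensitive to its substituent: cyano in place of fluoro on an aromatic carbon gave a number 18.2 percentage points lower from compound 3 to compound 4 (beyond the scatter), the first step to pass the scatter. The same separation appears against the other two aryl groups, with a number 20.8 percentage points lower from compound 2 to compound 4 (beyond the scatter) and a number 14.5 percentage points lower from compound 1 to compound 4 (beyond the scatter), whereas those three earlier aryl groups stayed within the scatter of one another. Nothing available accounts for this drop.

It remains open whether the drop belongs to cyano as such or to cyano at this place, since the compounds shown carry it only meta to a large group. From the compounds shown here alone, it is also open how other groups at that place, such as an amine, a carboxylic acid or a methoxy group, would read.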